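Replacing 3-aminophenyl with 4-methoxyphenyl on the shared core

The source may hold more compounds than are shown below. What is called first, only, known or untested is meant among the compounds shown, and "the series" means these compounds.

In a functional assay on MCF7 cells (Homo sapiens) for antiproliferative activity, read by MTT assay, with a stated time of 72 h (a lower number here means a stronger inhibitor, a higher number a weaker inhibitor), compound 1 `CCOc1ccc(-c2ccc3ncn(-c4cc(OC)c(OC)c(OC)c4)c3c2)cc1` gives 1710 nM, compound 2 `COc1cc(-n2cnc3ccc(-c4ccc(C)cc4F)cc32)cc(OC)c1OC` gives 56 nM and compound 3 `COc1cc(-n2cnc3ccc(-c4cccc(N)c4)cc32)cc(OC)c1OC` gives 180 nM, the second highest of the three numbers. Compound 4 `COc1ccc(-c2ccc3ncn(-c4cc(OC)c(OC)c(OC)c4)c3c2)cc1` has 4-methoxyphenyl in place of 3-aminophenyl on an aromatic carbon. Three measured steps at this carbon bear on the change: the large 31-fold lower number from compound 1 to compound 2 (1.48 log units; beyond the scatter), the modest 9.5-fold lower number from compound 1 to compound 3 (0.98 log units; beyond the scatter) and the modest 3.2-fold higher number from compound 2 to compound 3 (0.51 log units; beyond the scatter). Among the measured groups, the 4-ethoxyphenyl of compound 1, at 1710 nM, is the closest by name to 4-methoxyphenyl. A modest step to a higher number is therefore expected in this assay, estimated as a 3.3-fold higher number from compound 3 to compound 4 (0.52 log units; beyond the scatter). Compound 4 is estimated at 600 nM, within an expected range of 120 nM to 2000 nM.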

Compound 4, half-maximal inhibitory concentration: 210 nM
The estimate for compound 4 lay 2.9-fold (0.46 log units) above the measured number; the range from low to high includes it.
By their numbers in this assay, from the lowest: compound 2; then compounds 3 and 4 (each within the scatter of the next); then compound 1.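

In this assay, 4-methoxyphenyl and 3-aminophenyl cannot be told apart at this aromatic carbon, with a 1.2-fold higher number from compound 3 to compound 4 (0.07 log units; within the scatter). The single methyl that separates 4-ethoxyphenyl from 4-methoxyphenyl matters far more, with an 8.1-fold lower number from compound 1 to compound 4 (0.91 log units; beyond the scatter). The 2-fluoro-4-methylphenyl group keeps the lowest number, with a 3.8-fold higher number from compound 2 to compound 4 (0.57 log units; beyond the scatter).

Nothing available explains these steps. Going by these compounds, whether 4-propoxyphenyl or 4-hydroxyphenyl would fall nearer compound 4 or compound 1 stays open.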